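Methoxy for Chloro on Two Related Cores

The source may report more compounds than this note shows. Statements on the series, on what has been measured and on what is new or still open speak of the compounds shown alone.

The measured compounds are compound 1 `Cn1c(N2N=C(c3ccccc3)CC2c2ccc(Cl)cc2)nc(-c2ccccc2)c(C#N)c1=O`, compound 2 `COc1ccc(C2CC(c3ccccc3)=NN2c2nc(-c3ccccc3)c(C#N)c(=O)n2C)cc1` and compound 3 `Cn1c(N2N=C(c3ccccc3)CC2c2ccc(Cl)cc2)nc(-c2ccc(Cl)cc2)c(C#N)c1=O`. In a functional assay on MCF7 cells (Homo sapiens) for antiproliferative activity, with a stated time of 72 h (a higher number here means a weaker inhibitor, a lower number a stronger inhibitor), compound 1 gives 3280 nM, compound 2 gives 18000 nM and compound 3 gives 46300 nM.

Compound 4 `COc1ccc(C2CC(c3ccccc3)=NN2c2nc(-c3ccc(Cl)cc3)c(C#N)c(=O)n2C)cc1` has not been measured. It differs from compound 3 by methoxy in place of chloro on an aromatic carbon, the same change that separates compound 1 from compound 2, (methoxy in place of chloro on an aromatic carbon). That change brought a 5.5-fold higher number from compound 1 to compound 2 (0.74 log units; beyond the scatter). The two cores differ by chloro in place of hydrogen on an aromatic carbon, a change that itself brought a 14-fold higher number from compound 1 to compound 3 (1.15 log units; beyond the scatter), so compound 3 already stands at the high end of the three numbers.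

Because the step of a 5.5-fold higher number from compound 1 to compound 2 (0.74 log units; beyond the scatter) was seen on the core of compound 1, compound 4 is expected to show a step of similar direction and size, a 3.2-fold higher number from compound 3 to compound 4 (0.51 log units; beyond the scatter). For compound 4 the estimate in this assay is therefore 150000 nM, within 40000 nM to 500000 nM, with a real chance that the assay reports only a limit.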

Compound 4, half-maximal inhibitory concentration: 52400 nM
Compound 4: the middle estimate sits 2.9-fold (0.46 log units) above what was measured; low and high end bracket the measured number.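

In this assay the change from 4-chlorophenyl to 4-methoxyphenyl gives a 1.1-fold higher number from compound 3 to compound 4 (0.05 log units; within the scatter) and so did not carry over at the size seen on the core of compound 1: (the same change on two cores in this assay, a 5.5-fold higher number (0.74 log units; beyond the scatter) from compound 1 to compound 2 and a 1.1-fold higher number (0.05 log units; within the scatter) from compound 3 to compound 4, 4.8-fold (0.69 log units) apart, beyond the scatter of two such steps). The chloro in place of hydrogen change gives a 2.9-fold higher number from compound 2 to compound 4 (0.46 log units; beyond the scatter) and likewise keeps its direction but not its size across the two cores: (the same change on two cores in this assay, a 14-fold higher number (1.15 log units; beyond the scatter) from compound 1 to compound 3 and a 2.9-fold higher number (0.46 log units; beyond the scatter) from compound 2 to compound 4, 4.8-fold (0.69 log units) apart, beyond the scatter of two such steps). These four compounds show that neither step transfers unchanged between these cores, but they do not show why, and they offer no rule for a third core.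

As far as these compounds go, it remains open how an amine or a carboxylic acid would behave in place of the chloro. From the compounds shown here alone, a longer chain in place of the methoxy is equally open.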